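The source may hold more compounds than are shown below. What is called first, only, known or untested is meant among the compounds shown, and "the series" means these compounds.

Among the measured compounds shown here, compound 2 `CCNC(=O)c1cc(N)c(Nc2ccc(C#N)cc2)cc1Oc1c(C)cc(/C=C/C#N)cc1C` is the only member of this small set with a numerical reading in a physicochemical assay for lipophilicity, read by HPLC, measured as octanol-water partition, with a stated time of 24 h, at pH 7.4; on this read-out higher numbers stand for higher lipophilicity and lower numbers for lower lipophilicity: in that assay compound 2 gives 3.63. Compound 1 `COCCOC(=O)c1cc(N)c(Nc2ccc(C#N)cc2)cc1Oc1c(C)cc(/C=C/C#N)cc1C` has also been run, but for compound 1 the reading of > 5 is a limit rather than a number (the limit of > 5 in this assay, at which 1 of the 2 values shown sits). For the measured compounds named here, the single measured step between the two runs a number at least 1.37 log units lower from compound 1 to compound 2 (beyond the scatter). Compound 3 `Cc1cc(/C=C/C#N)cc(C)c1Oc1cc(Nc2ccc(C#N)cc2)c(N)cc1C(=O)NN` has not yet been measured in this assay. It differs from compound 2 by amino in place of ethyl on an amide-type nitrogen. The measured step concerns a different site, a carbonyl carbon, so it bears only loosely on this change; it does show that exchanging one substituent on the shared core can move the reading by a large amount. Compound 3 is expected to read lower, with an estimated step of a number 1.33 log units lower from compound 2 to compound 3 (beyond the scatter). The estimate for compound 3 is 2.3, with a range from 1.6 to 3.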

Compound 3, partition coefficient: 2.31
Compound 3: the middle estimate sits 0.01 log units below what was measured, and the stated range covers the measured number.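

On the amide-type nitrogen, whose other neighbour is the carbonyl carbon, amino in place of ethyl gives a large change in this assay (a number 1.32 log units lower from compound 2 to compound 3 (beyond the scatter)), the only measured change at this nitrogen among the compounds shown, as the earlier step lay on a carbonyl carbon. Comparing the two ends of the set gives a still wider step (a number at least 2.69 log units lower from compound 1 to compound 3 (beyond the scatter)). Compound 1 reads > 5, which is a limit and not a number, so that step is bounded on one side only: (the limit of > 5 in this assay, at which 1 of the 3 values shown sits).

The compounds shown leave open how the reading runs across other groups on this nitrogen. A single pair cannot tell where a methyl, a propyl chain or a hydroxyl there would fall relative to ethyl and amino.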